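The source may hold more compounds than are shown below. What is called first, only, known or untested is meant among the compounds shown, and "the series" means these compounds.

Compound 1 `CN(C)CCn1c(N)c(-c2nc3ccccc3n2C)c2nc(C#N)c(C#N)nc21` – in a functional assay on HL-60 cells (Homo sapiens) for antiproliferative activity, read by MTT assay, with a stated time of 48 h; a higher number here means a weaker inhibitor, a lower number a stronger inhibitor: > 50000 nM, a limit and not a number
Compound 2 `CCN(CC)CCn1c(N)c(-c2nc3ccccc3n2C)c2nc(C#N)c(C#N)nc21` – in this assay: 8800 nM
Compound 3 `CN(C)CCCCn1c(-c2c(N)n(C)c3nc(C#N)c(C#N)nc23)nc2ccccc21` – in this assay: 2270 nM

Of the compounds shown here, three have been measured so far. Compounds 1 and 2 share one core; compound 3 is built on another, and the difference between the two cores is not broken down here. Compound 1 gives only a limit in this assay, > 50000 nM, and no number. Compound 2 carries the change (diethylamino in place of dimethylamino on a saturated chain carbon, two bonds along the chain from an aromatic nitrogen), and the step is an at least 5.6-fold lower number from compound 1 to compound 2 (0.75 log units; beyond the scatter); since the starting point is the limit of > 50000 nM in this assay, at which 1 of the 3 values shown sits, only the floor of that step is known. Compound 3 gives 2270 nM, the lowest of the two numbers and lower than that of compound 2.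

Compound 4 `CCN(CC)CCCCn1c(-c2c(N)n(C)c3nc(C#N)c(C#N)nc23)nc2ccccc21` has not yet been measured in this assay. It differs from compound 3 by diethylamino in place of dimethylamino on a saturated chain carbon, four bonds along the chain from an aromatic nitrogen. This is the same kind of change as that from compound 1 to compound 2, though not the same: there the place was two bonds along the chain from an aromatic nitrogen, here it is four bonds along the chain from an aromatic nitrogen. From compound 3 to compound 4 a step of a 2.5-fold lower number from compound 3 to compound 4 (0.40 log units; beyond the scatter) is expected, a lowering that rests on the earlier step of an at least 5.6-fold lower number from compound 1 to compound 2 (0.75 log units; beyond the scatter), tempered because that step is only a floor read from the limit of > 50000 nM in this assay, at which 1 of the 3 values shown sits, and compound 3 already sits lower. Compound 4 is therefore estimated at 900 nM, plausibly between 300 nM and 2500 nM.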

Compound 4, half-maximal inhibitory concentration: 2860 nM
Beside the measured number, compound 4's estimate is 3.2-fold (0.50 log units) below it; measured number above the stated range.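

In this assay, diethylamino in place of dimethylamino, four bonds along the chain from an aromatic nitrogen, gives a 1.3-fold higher number from compound 3 to compound 4 (0.10 log units; within the scatter), so on this core the two amines cannot be told apart, and the clear drop in the number seen on the other core does not carry over: the same change on two cores in this assay, an at least 5.6-fold lower number (0.75 log units; beyond the scatter) from compound 1 to compound 2 and a 1.3-fold higher number (0.10 log units; within the scatter) from compound 3 to compound 4, at least 7.1-fold (0.85 log units) apart, beyond the scatter of two such steps The earlier step starts from compound 1, whose value is a limit and not a number, so only a floor is known for the size of that step and for the gap between the two steps: the limit of > 50000 nM in this assay, at which 1 of the 4 values shown sits. What this does not show is why the steps differ, since the two pairs differ both in their core and in the place of the change, two bonds along the chain in one and four bonds along it in the other, and the data cannot separate these two differences.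

From the compounds shown here alone, it remains open how the same change would read with the amine four bonds along the chain on the core of compound 1, or two bonds along it on the core of compound 3. Also open, going by these compounds, is how a cyclic amine, a primary amine or a longer chain would read in this assay on either core.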